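Aryl in place of methoxy on the sulfonyl arene

The source may hold more compounds than are shown below. What is called first, only, known or untested is meant among the compounds shown, and "the series" means these compounds.

Compound 3 `COc1cccc(S(=O)(=O)N2CCC(N3CCC(C)CC3)CC2)c1` reports only a limit in a functional assay on DLD-1 cells (Homo sapiens) for antiproliferative activity, read by CellTiter-Glo, with a stated time of 72 h (a higher number here means a weaker inhibitor, a lower number a stronger inhibitor), namely > 5000 nM. That value is a limit of the assay, not a number: the limit of > 5000 nM in this assay, at which 1 of the 3 values shown sits. Compound 1 `CC1CCN(C2CCN(S(=O)(=O)c3cccc(N)c3)CC2)CC1` gives 3400 nM in this assay, and compound 2 `CC1CCN(C2CCN(S(=O)(=O)c3cccc(-c4ccc5ccccc5c4)c3)CC2)CC1` gives 2 nM. Compound 4 `CC1CCN(C2CCN(S(=O)(=O)c3cccc(-c4ccc(Cl)cc4)c3)CC2)CC1` differs from compound 3 by 4-chlorophenyl in place of methoxy on an aromatic carbon. Within the data shown here, two measured steps bear on this change: a 1700-fold lower number from compound 1 to compound 2 (3.23 log units; beyond the scatter) and an at least 2500-fold higher number from compound 2 to compound 3 (3.39 log units; beyond the scatter), both large and in the same sense. By contrast an at least 1.4-fold higher number from compound 1 to compound 3 (0.16 log units; that floor lies within the scatter), which stays inside the scatter. An aryl group entering at this position is therefore expected to lower the number sharply, so a step of an at least 250-fold lower number from compound 3 to compound 4 (2.39 log units; beyond the scatter) is expected. For compound 4 the estimate is 20 nM, with a range from 5 nM to 150 nM.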

Compound 4, half-maximal inhibitory concentration: 15 nM
Compound 4: the middle estimate sits 1.3-fold (0.12 log units) above what was measured; low and high end bracket the measured number.
By their numbers in this assay, from the lowest: compound 2; then compound 4; then compound 1. At a limit, above all of these: compound 3.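

In this assay, the gain at this position is not confined to naphthalen-2-yl: a single 4-chlorophenyl ring also gives a 230-fold lower number from compound 1 to compound 4 (2.36 log units; beyond the scatter). The step of an at least 330-fold lower number from compound 3 to compound 4 (2.52 log units; beyond the scatter) rests on a limit, not a number: the limit of > 5000 nM in this assay, at which 1 of the 4 values shown sits.

The two aryl groups are still not interchangeable, with a 7.5-fold higher number from compound 2 to compound 4 (0.88 log units; beyond the scatter).

From the compounds shown here alone, the contribution of the chlorine remains open, and a plain phenyl at this position would address it. Also open, going by these compounds, is whether a pyridyl ring or a saturated ring such as cyclohexyl would keep the gain.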